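A few compounds are considered here, and "the series" means these few. Any claim that something is new, unique, unknown or untested is made for them only; others in the source may bear on it.

Measured so far in a physicochemical assay for solubility, read by HPLC, in simulated intestinal fluid, with a stated time of 16 h, at pH 6.5; on this read-out lower numbers stand for lower solubility and higher numbers for higher solubility:
compound 1 `CNC(=O)c1cc(C(=O)N[C@H]2CC[C@H](O)CC2)c([C@@H](C)c2cccc(Cl)c2)o1` gives 408 ug/mL
compound 2 `CNC(=O)c1cc(C(=O)N[C@H]2[C@@H]3C[C@H](O)C[C@@H]32)n([C@@H](C)c2cccc(Cl)c2)n1` gives 327 ug/mL
compound 3 `CCC(=O)c1c[nH]c(C(=O)NC)c1` gives 13 ug/mL

Repeat measurements of this kind never agree exactly, so a small gap between two numbers means little. Compound 1 and compound 2 lie within that usual scatter of each other, and their numbers cannot be told apart. Compound 3 lies far lower, well beyond the scatter. Compound 1 therefore belongs to the upper pair of this small set.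

The next compound to test is compound 4 `CNC(=O)c1cc(C(=O)N[C@H]2CC[C@H](O)CC2)c([C@@H](C)c2ccccc2)o1`, which differs from compound 1 in one place only: hydrogen in place of chloro on an aromatic carbon. In plain words, hydrogen stands in place of chloro on an aromatic carbon, so that 3-chlorophenyl becomes phenyl.

Within the data shown here, no two measured compounds differ in a single place, so no measured step shows what this change does. Among the measured compounds shown here, the only firm anchor is compound 1 at 408 ug/mL, and the expectation stays close to it. The estimated step is a 1.4-fold higher number from compound 1 to compound 4 (0.14 log units; within the scatter), a small upward move that is expected to stay within the scatter. For compound 4 the estimated value is 560 ug/mL, with an expected range from 250 ug/mL to 1200 ug/mL.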

Compound 4, solubility: 827 ug/mL
Compound 4: the middle estimate sits 1.5-fold (0.17 log units) below what was measured; measured number inside the range.
By their numbers in this assay, from the lowest: compound 3; then compounds 2 and 1 (each within the scatter of the next); then compound 4.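

In this assay, among these compounds, this is the first comparison in the set where only one place changes, and going from 3-chlorophenyl to phenyl gives a 2.0-fold higher number from compound 1 to compound 4 (0.31 log units; beyond the scatter). The step is modest, but it shows that a single substituent on this aromatic ring can move the number beyond the usual scatter, even though the change involves no hydrogen-bond donor or acceptor and no net charge. Nothing measured here explains why the number moves, so this single step records an effect without giving its cause.

Going by these compounds, with only chloro and hydrogen compared at this place on the ring, it remains open how other groups there, such as fluoro, methoxy or a carboxylic acid, would behave. On these data alone, it is also open whether removing chloro would produce a similar step in compound 2, which carries the same 1-(3-chlorophenyl)ethyl group on a different core, or whether this result holds only for the core of compound 1.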